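Swapping Benzyloxy for Isobutyl on a Shared Core

The source may report more compounds than this note shows. Statements on the series, on what has been measured and on what is new or still open speak of the compounds shown alone.

Compound 1, `COCCOc1cc2oc(=O)n(CCC(=O)O)c2cc1Cl`, in an assay for inhibition of kynurenine 3-monooxygenase (Homo sapiens), read by mass spectrometry, with a stated time of 1 h (on this read-out lower numbers stand for stronger inhibition and higher numbers for weaker inhibition), gives 31.6 nM.
Compound 2, `CCc1cc2oc(=O)n(CCC(=O)O)c2cc1Cl`, in this assay gives 10 nM.
Compound 3, `O=C(O)CCn1c(=O)oc2cc(OCc3ccccc3)c(Cl)cc21`, in this assay gives 25.1 nM.

All three share one core and differ only in the group on one aromatic carbon. Compound 3 sits second highest of the three numbers: its gap to compound 1 is within the usual scatter, while a 2.5-fold higher number from compound 2 to compound 3 (0.40 log units; beyond the scatter) is a modest step beyond it. Compound 4, `CC(C)Cc1cc2oc(=O)n(CCC(=O)O)c2cc1Cl`, is the next member of this set. The change is isobutyl in place of benzyloxy on an aromatic carbon.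

Within the data shown here, two measured steps bear on this. a 2.5-fold higher number from compound 2 to compound 3 (0.40 log units; beyond the scatter) shows that replacing ethyl, a carbon chain without an oxygen, with benzyloxy raised the number; reversing that direction toward isobutyl, again a carbon chain with no hydrogen-bond acceptor, should undo that rise. Likewise a 3.2-fold lower number from compound 1 to compound 2 (0.50 log units; beyond the scatter) shows a lower number when ethyl replaced an oxygen-bearing chain. Among the measured compounds shown here, a modest downward step is therefore expected in this assay, roughly matching the step from compound 2 to compound 3 in reverse, though the larger isobutyl chain has no exact precedent here. Compound 4 is estimated at 12 nM, within 5 nM to 30 nM, an expected step of a 2.1-fold lower number from compound 3 to compound 4 (0.32 log units; beyond the scatter).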

Compound 4, half-maximal inhibitory concentration: 12.6 nM
The estimate for compound 4 lay 1.1-fold (0.02 log units) below the measured number, and the stated range covers the measured number.
By their numbers in this assay, from the lowest: compounds 2, 4, 3 and 1 (each within the scatter of the next, the first and the last beyond it).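

Compound 4 shows that this aromatic carbon can carry a larger carbon-only chain than ethyl without a measurable change in this assay: there is a 1.3-fold higher number from compound 2 to compound 4 (0.10 log units; within the scatter), and that step lies within the scatter. The exchange of benzyloxy for isobutyl, which removes an aromatic ring and an oxygen, gives a 2.0-fold lower number from compound 3 to compound 4 (0.30 log units; within the scatter), also within the scatter, so compound 4 cannot be separated from either compound 2 or compound 3, even though a 2.5-fold higher number from compound 2 to compound 3 (0.40 log units; beyond the scatter) separates those two. Only the comparison with the 2-methoxyethoxy compound clears the scatter, with a 2.5-fold lower number from compound 1 to compound 4 (0.40 log units; beyond the scatter), but no measurement shown here gives a reason for any of these steps.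

The compounds shown leave open whether the ring or the oxygen of benzyloxy matters more, a question that a benzyl group on the same carbon, which keeps the ring but lacks that oxygen, could help to separate. They also leave open how far this position tolerates growth, since a longer chain such as hexyl, or an amine, would test it beyond isobutyl.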